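Replacing Isopropyl with a Carbamoylcyclohexyl Group

A few compounds are considered here, and "the series" means these few. Any claim that something is new, unique, unknown or untested is made for them only; others in the source may bear on it.

In an ADME assay on Caco-2 cells (Homo sapiens) for permeability, in the apical to basolateral direction (a lower number here means that the compound crosses the layer more slowly, a higher number that the compound crosses the layer faster), compound 1 `CC(C)c1ccn2ncnc(N[C@H]3CC[C@H](N(C)C)CC3)c12` gives 26 10^-6 cm/s, and compound 2 `COC(=O)N1CCN([C@H]2CC[C@H](Nc3ncnn4ccc([C@H](C)CC(=O)N(C)C)c34)CC2)CC1` gives 18 10^-6 cm/s in this assay; these two values sit within the scatter of each other, so compound 1 stands alongside compound 2 rather than apart from it. Compound 3 `CN(C)[C@H]1CC[C@H](Nc2ncnn3ccc([C@H]4CC[C@H](C(N)=O)CC4)c23)CC1` has not yet been measured in this assay. It differs from compound 1 by 4-carbamoylcyclohexyl in place of isopropyl on an aromatic carbon. For the measured compounds named here, no measured step of this kind exists here. The step of a 2.6-fold lower number from compound 1 to compound 3 (0.41 log units; beyond the scatter) is expected to run downward, beyond the scatter. Compound 3 is estimated at 10 10^-6 cm/s, with a range from 4 10^-6 cm/s to 20 10^-6 cm/s.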

Compound 3, apparent permeability: < 0.8 10^-6 cm/s
Compound 3 ended at the assay's limit (the forecaster's own chance of this, stated with the estimate: 3%); at least 12-fold (1.09 log units) between middle value and limit.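

For the compounds shown here, this is the first measured step at this aromatic carbon, and it shows that the group placed there can move the read-out by a large margin. In this assay, 4-carbamoylcyclohexyl in place of isopropyl gives an at least 32-fold lower number from compound 1 to compound 3 (1.51 log units; beyond the scatter). The value of compound 3 is a limit of the assay and not a number, so the true size of the step stays unknown: the limit of < 0.8 10^-6 cm/s in this assay, at which 1 of the 3 values shown sits.

The compounds shown leave open whether the step belongs to the six-membered ring or to the carbamoyl group. A plain cyclohexyl group or a cyclohexyl ring carrying a methyl ester at this place would separate the two.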